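Cytotoxicity of three amides and a pyridyl analogue

The source may hold more compounds than are shown below. What is called first, only, known or untested is meant among the compounds shown, and "the series" means these compounds.

Compound 1, `COc1ccc(-c2cnc(NC(=O)c3ccno3)n2C)cc1`: in a toxicity assay on THP-1 cells (Homo sapiens) for inhibition (a lower number here means that less compound is tolerated, a higher number that more compound is tolerated), compound 1 gives > 100000 nM, a limit of the assay.
Compound 2, `COc1ccc(-c2cnc(NC(=O)c3ccccc3C#N)n2C)cc1`: in this assay compound 2 gives > 100000 nM, again a limit.
Compound 3, `COc1ccc(-c2cnc(NC(=O)c3cccc(Cl)c3)n2C)cc1`: in this assay compound 3 gives > 28000 nM, also a limit.

Compound 3 therefore stands only at a limit in this assay, and the two other values shown are limits as well; this is the limit of > 28000 nM in this assay, at which 1 of the 3 values shown sits, against (the limit of > 100000 nM in this assay, at which 2 of the 3 values shown sit). None of the three steps among the measured compounds can be read: a step that the two limits leave unreadable from compound 1 to compound 2, a step that the two limits leave unreadable from compound 1 to compound 3 and a step that the two limits leave unreadable from compound 2 to compound 3 all sit between limits. The step to the unmeasured compound 4, `COc1ccc(-c2cnc(NC(=O)c3ccncc3)n2C)cc1`, is pyridin-4-yl in place of 3-chlorophenyl on a carbonyl carbon. All three measured steps bear on it, since each exchanges the group on the carbonyl carbon, yet none gives a readable size. No step beyond the scatter is expected in this assay for compound 4, which is estimated as a step that the limit leaves unreadable from compound 3 to compound 4. Compound 4 is thus expected at 100000 nM, within 30000 nM to 300000 nM, most likely again only as a limit.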

Compound 4, half-maximal cytotoxic concentration: > 100000 nM
Compound 4: only a limit was reported; the forecaster's own chance of this, stated with the estimate: 85%; the middle value sits exactly at the limit.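

In this assay compound 4 gives > 100000 nM, again a limit. Its steps to compound 1, compound 2 and compound 3 all sit between limits and cannot be read. The compounds shown leave open at what concentration any of them turns cytotoxic, and whether the group on the carbonyl carbon changes that.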